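A few compounds are considered here, and "the series" means these few. Any claim that something is new, unique, unknown or untested is made for them only; others in the source may bear on it.

Measured compounds in a functional assay on UACC-62 cells (Homo sapiens) for inhibition, read by sulforhodamine B assay, with a stated time of 48 h; on this read-out higher numbers stand for weaker inhibition of growth and lower numbers for stronger inhibition of growth:
compound 1, `Nc1cc(N)c2nc(-c3ccccc3)c(NCc3ccc(Cl)c(Cl)c3)nc2c1`, gives 14100 nM
compound 2, `Nc1cc(N)c2nc(-c3ccccc3)c(Sc3ccc(F)cc3)nc2c1`, gives 16600 nM
compound 3, `CCOC(=O)[C@H](CCC(=O)O)NC(=O)c1ccc(CNc2nc3cc(N)cc(N)c3nc2-c2ccccc2)cc1`, is reported only as a limit, < 100000 nM

Three compounds share the core of compound 1 and differ in the group attached beside the phenyl substituent. Compound 2 carries the higher of the two numbers, but its gap to compound 1 lies within the scatter of repeated measurements, so the two cannot be ranked against each other. For compound 3 the assay gives a limit and no number, so that compound adds nothing to a comparison of sizes. The value of compound 3 sits at the limit described as the limit of < 100000 nM in this assay, at which 1 of the 3 values shown sits.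

Compound 4, `COc1ccc(Sc2nc3cc(N)cc(N)c3nc2-c2ccccc2)cc1`, has not yet been measured. It differs from compound 2 in one place: methoxy in place of fluoro on an aromatic carbon. Going by the values given here, no measured pair in this set shows such a change, so there is nothing to lean on for its direction. The change is small and keeps the same (4-substituted phenyl)sulfanyl arrangement, so the expected step is about a 1.1-fold lower number from compound 2 to compound 4 (0.04 log units; within the scatter), which would lie within the scatter. Compound 4 is therefore estimated at 15000 nM, with a plausible range from 6000 nM to 40000 nM.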

Compound 4, concentration for 50% growth inhibition: 38000 nM
Compound 4: the middle estimate sits 2.5-fold (0.40 log units) below what was measured; the range from low to high includes it.
By their numbers in this assay, from the lowest: compounds 1 and 2 (each within the scatter of the next); then compound 4.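

In this assay, methoxy in place of fluoro on this aromatic carbon gives a 2.3-fold higher number from compound 2 to compound 4 (0.36 log units; beyond the scatter), a modest step towards weaker inhibition of growth. Going by these compounds alone, this is the first pair in the set that differs in only one place, and it shows that the group at the end of the (4-substituted phenyl)sulfanyl arrangement can shift the read-out beyond the scatter, even though the change is small. Nothing measured here offers a reason for this step.

Within the data shown here, the single pair gives the direction for these two groups only, so it remains open where a hydroxyl, an amine or a chlorine at the same place would fall. Going by these compounds, it is also open whether the same change would have a similar effect with an amine in place of the sulfur link.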